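From compound 3 to its azido counterpart, compound 4

This account rests on a few compounds, and the source may have more. Where it says the series, first, only, none or still open, it means among the compounds named here.

Measured in a functional assay on SW480 cells (Homo sapiens) for antiproliferative activity, read by MTT assay, with a stated time of 48 h (a lower number here means a stronger inhibitor, a higher number a weaker inhibitor), so far
- compound 1 `CC(C)=CCC[C@]1(C)/C=C/[C@@H](OC(=O)C=C(C)C)[C@](C)(O)/C=C/C(=O)/C(C(=O)O)=C\C1` gives > 10000 nM
- compound 2 `CCN(CC)C/C1=C/C[C@](C)(CCC=C(C)C)/C=C/[C@@H](OC(=O)C=C(C)C)[C@](C)(O)/C=C/C1=O` gives 270 nM
- compound 3 `CC[Si](CC)(CC)C/C1=C/C[C@](C)(CCC=C(C)C)/C=C/[C@@H](OC(=O)C=C(C)C)[C@](C)(O)/C=C/C1=O` gives 2690 nM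

Compound 1 shows > 10000 nM, which is a limit of the assay and not a number. Compound 3, with 2690 nM as its value, holds the higher of the two actual numbers. Compound 4 `CC(C)=CCC[C@]1(C)/C=C/[C@@H](OC(=O)C=C(C)C)[C@](C)(O)/C=C/C(=O)/C(CN=[N+]=[N-])=C\C1` has not yet been measured. The change to it is a group of 3 heavy atoms (3 nitrogen; no ring) in place of a group of 7 heavy atoms (6 carbon, 1 silicon; no ring), on a saturated chain carbon bound to a double-bonded ring carbon on a saturated chain carbon bound to a double-bonded ring carbon.

Among the measured compounds shown here, the closest guide is a 10-fold higher number from compound 2 to compound 3 (1.00 log units; beyond the scatter) as the one measured step at that place. The steps of an at least 37-fold lower number from compound 1 to compound 2 (1.56 log units; beyond the scatter) and an at least 3.7-fold lower number from compound 1 to compound 3 (0.57 log units; beyond the scatter) are less direct since both replace carboxy on a double-bonded ring carbon. Azido has no measured counterpart here, so neither direction is favoured. The estimated change is a 1.3-fold lower number from compound 3 to compound 4 (0.13 log units; within the scatter) and no step beyond the scatter is expected, though with wide uncertainty. Compound 4 is estimated at 2000 nM with an expected range from 500 nM to 8000 nM in this assay overall.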

Compound 4, half-maximal inhibitory concentration: 4230 nM
For compound 4 the middle estimate is 2.1-fold (0.33 log units) below the measured one; low and high end bracket the measured number.
By their numbers in this assay, from the lowest: compound 2; then compounds 3 and 4 (each within the scatter of the next). At a limit, above all of these: compound 1.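

In this assay, azido and the silicon-bearing group of compound 3 cannot be told apart on this saturated chain carbon bound to a double-bonded ring carbon (a 1.6-fold higher number from compound 3 to compound 4 (0.20 log units; within the scatter)), while azido stays well apart from diethylamino (a 16-fold higher number from compound 2 to compound 4 (1.19 log units; beyond the scatter)). Azidomethyl in place of carboxy also gives a step beyond the scatter (an at least 2.3-fold lower number from compound 1 to compound 4 (0.37 log units; beyond the scatter)), so the azido compound does not fall back to the carboxy compound. On these data alone, compound 1 stands at a limit and not a number, so the size of that step stays unknown: the limit of > 10000 nM in this assay, at which 1 of the 4 values shown sits.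

The compounds shown leave open whether a different amine, such as dimethylamino or morpholine, would match diethylamino at this place. They also leave open whether a primary amine or a longer chain carrying the diethylamino group would read the same way.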